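The source may hold more compounds than are shown below. What is called first, only, known or untested is meant among the compounds shown, and "the series" means these compounds.

Measured compounds in an assay on isolated protein for inhibition of MAP/microtubule affinity-regulating kinase 3 (Homo sapiens), read by HTRF; a lower number here means a stronger inhibitor, a higher number a weaker inhibitor:

compound 1 `Cn1cc(N2C(=O)c3nc(Nc4ccccc4)ncc3C2(C)C)cn1`: there compound 1 gives > 30000 nM.
compound 2 `CC1(C)C(=O)N(c2ccccc2)c2nc(Nc3ccccc3)ncc21`: there compound 2 gives 2800 nM.
compound 3 `CC1(C)C(=O)N(C(C)(C)c2ccccc2)c2nc(Nc3cccnc3)ncc21`: there compound 3 gives 1640 nM.

Compound 1 sits at a limit of this assay and not at a number (the limit of > 30000 nM in this assay, at which 1 of the 3 values shown sits). Compound 3 holds the lowest of the two numbers shown, and its nearest neighbour, compound 2, sits within the scatter of it, so the two cannot be told apart.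

The next step is compound 4 `C[C@@H](c1ccc(F)cc1)N1C(=O)C(C)(C)c2cnc(Nc3cccnc3)nc21`, which differs from compound 3 in one place: 1-(4-fluorophenyl)ethyl in place of 1-methyl-1-phenylethyl on an amide-type nitrogen in a ring. Within the data shown here, no measured pair shows such a change, so the size of the step in this assay is open. A defined stereocentre enters here; a modest move towards a stronger inhibitor is expected, by a 2.3-fold lower number from compound 3 to compound 4 (0.37 log units; beyond the scatter). For compound 4 an estimate of 700 nM is made, within 150 nM to 3000 nM.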

Compound 4, half-maximal inhibitory concentration: 62 nM
Compound 4: the middle estimate sits 11-fold (1.05 log units) above what was measured; measured number outside the range, below it.
By their numbers in this assay, from the lowest: compound 4; then compounds 3 and 2 (each within the scatter of the next). At a limit, above all of these: compound 1.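

The amide-type nitrogen in a ring responds strongly to the group it carries: in this assay, 1-(4-fluorophenyl)ethyl in place of 1-methyl-1-phenylethyl gives a 26-fold lower number from compound 3 to compound 4 (1.42 log units; beyond the scatter), although both groups hold the same count of heavy atoms and one six-membered aromatic ring of carbon only. Compound 4 is the only compound shown with a defined stereocentre. Among these compounds, nothing measured so far accounts for this step.

The fluorine and the stereocentre enter together, so their shares cannot be separated, and the mirror-image form of compound 4 remains unplaced. From the compounds shown here alone, whether an amine or a carboxylic acid on that aromatic ring would be tolerated also stays open.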